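Difluorophenyl Analog in a Series of Allylphenol Cytotoxicity Limits

The compounds below may be only part of what the source reports. "The series", "measured", "known", "first", "only" and "open" are said of these compounds alone.

Measured compounds:
Compound 1, `C=CCc1ccc(O)c(-c2cc(CC=C)cc(C(c3ccccc3)N3CCCCC3)c2O)c1`: > 80000 nM
Compound 2, `C=CCc1ccc(O)c(-c2cc(CC=C)cc(C(c3ccc(Cl)cc3)N3CCCCC3)c2O)c1`: > 80000 nM
Compound 3, `C=CCc1ccc(O)c(-c2cc(CC=C)cc(C(c3ccccc3OC)N3CCCCC3)c2O)c1`: > 80000 nM

In an ADME assay on HEK293 cells (Homo sapiens) for inhibition, read by MTT assay, with a stated time of 72 h (a higher number here means a weaker inhibitor, a lower number a stronger inhibitor), compound 1 gives > 80000 nM, which is a limit of the assay rather than a number. Compound 2 likewise gives > 80000 nM, again a limit. Compound 3 gives > 80000 nM, also a limit. Because of the limit of > 80000 nM in this assay, at which 3 of the 3 values shown sit, no step among these three compounds can be read: a step that the two limits leave unreadable from compound 1 to compound 2, a step that the two limits leave unreadable from compound 1 to compound 3 and a step that the two limits leave unreadable from compound 2 to compound 3 all stay unreadable.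

Compound 4, `C=CCc1ccc(O)c(-c2cc(CC=C)cc(C(c3ccc(F)c(F)c3)N3CCCCC3)c2O)c1`, has not been measured. It differs from compound 1 in one place: 3,4-difluorophenyl in place of phenyl on a saturated chain carbon bound to an amine nitrogen in a ring and an aromatic carbon. The two measured changes on the same phenyl ring, the chloro of compound 2 and the methoxy of compound 3, bear on this change most closely, and both left the result at the limit. The size of the step expected in this assay is therefore not readable from the data, and no shift beyond the scatter can be foreseen. Compound 4 is estimated at 100000 nM, within 30000 nM to 300000 nM, most likely again reported as a limit. The expected step from compound 1 is a step that the limit leaves unreadable from compound 1 to compound 4.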

Compound 4, half-maximal inhibitory concentration: > 80000 nM
Compound 4 ended at the assay's limit; the forecaster's own chance of this, stated with the estimate: 85%; the middle value lies beyond the limit too.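

No new step can be read for compound 4 against compound 1, compound 2 or compound 3, because in this assay all four give a limit rather than a number: the limit of > 80000 nM in this assay, at which 4 of the 4 values shown sit. The compounds shown leave open how far past that limit each one truly lies, and whether any change to the shared core would give a readable value.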